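The source may report more compounds than this note shows. Statements on the series, on what has been measured and on what is new or still open speak of the compounds shown alone.

In an assay for inhibition of MAP kinase-interacting serine/threonine-protein kinase 2 (Homo sapiens), read by luminescence and ADP-Glo, with a stated time of 2 h (on this read-out higher numbers stand for weaker inhibition and lower numbers for stronger inhibition), compound 3 `NC(=O)c1ccccc1Cn1cc(-c2ccc3cn[nH]c3c2)ccc1=O` gives 340 nM, the higher of the two numbers shown. Its nearest neighbour is compound 1 `O=c1ccc(-c2ccc3cn[nH]c3c2)cn1Cc1ccccc1C(F)(F)F`, which in this assay gives 100 nM. Compound 2 `O=C(N1CCOCC1)n1cc(-c2ccc3cn[nH]c3c2)ccc1=O` sits at the limit of > 2000 nM in this assay, at which 1 of the 3 values shown sits; its value of > 2000 nM is a limit of the assay and not a number. Within the data shown here, the one measured step between compounds that differ in a single place, a 3.4-fold higher number from compound 1 to compound 3 (0.53 log units; beyond the scatter), is a modest rise in the number that lies beyond the scatter.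

Compound 4 `O=c1ccc(-c2ccc3cn[nH]c3c2)cn1Cc1ccccc1Cl` differs from compound 3 by chloro in place of carbamoyl on an aromatic carbon. The step from compound 1 to compound 3 is the only one that bears on this exchange, as it also replaces the group on this aromatic carbon, and the chloro group, like trifluoromethyl, carries no hydrogen-bond donor or acceptor. A modest step back toward a lower number is therefore expected, with a 2.3-fold lower number from compound 3 to compound 4 (0.36 log units; beyond the scatter) as the estimated change for compound 4. The estimate for compound 4 in this assay is 150 nM, expected to fall between 60 nM and 400 nM.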

Compound 4, half-maximal inhibitory concentration: 78 nM
The estimate for compound 4 lay 1.9-fold (0.28 log units) above the measured number; the measured number falls inside the stated range.
By their numbers in this assay, from the lowest: compounds 4 and 1 (each within the scatter of the next); then compound 3. At a limit, above all of these: compound 2.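

In this assay, chloro and trifluoromethyl on this aromatic carbon cannot be told apart, since a 1.3-fold lower number from compound 1 to compound 4 (0.11 log units; within the scatter) is a step within the scatter. Carbamoyl alone stands apart among the three groups at this place: a 4.4-fold lower number from compound 3 to compound 4 (0.64 log units; beyond the scatter) runs opposite to the earlier step to carbamoyl, so both groups without carbamoyl's hydrogen-bond donor and acceptor give lower numbers than compound 3, though the data do not tie the difference to those counts. The step with 2-chlorobenzyl in place of (morpholin-4-yl)carbonyl on an aromatic nitrogen, an at least 25-fold lower number from compound 2 to compound 4 (1.40 log units; beyond the scatter), starts from compound 2, whose value is a limit and not a number: the limit of > 2000 nM in this assay, at which 1 of the 4 values shown sits.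

The compounds shown leave open how a nitrile, a methoxy group or an amine on this aromatic carbon would read. They also leave open whether chloro would give a similar number elsewhere on the benzyl ring.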